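The source may report more compounds than this note shows. Statements on the series, on what has been measured and on what is new or still open speak of the compounds shown alone.

Measured so far:
- compound 1, `O=C(COc1ccc2cc(/C=C3/SC(=O)NC3=O)ccc2c1)Nc1c(F)cc(F)cc1Br`; in an assay on isolated protein for inhibition of histone deacetylase 4 (Homo sapiens), with a stated time of 1 h (a higher number here means a weaker inhibitor, a lower number a stronger inhibitor), compound 1 gives 1100 nM
- compound 2, `Cc1cc(NC(=O)COc2ccc3cc(/C=C4/SC(=O)NC4=O)ccc3c2)no1`; in this assay compound 2 gives 1700 nM

Within the data shown here, compound 2 stands at the upper end of the two numbers, with compound 1 as its only neighbour; the step of a 1.5-fold higher number from compound 1 to compound 2 (0.19 log units; within the scatter) lies within the scatter, so the two numbers are not separated.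

The next compound is compound 3, `O=C(COc1ccc2cc(/C=C3/SC(=O)NC3=O)ccc2c1)Nc1ccc(Br)cc1`. It differs from compound 2 in one place: 4-bromophenyl in place of 5-methyl-1,2-oxazol-3-yl on an amide-type nitrogen.

Among the measured compounds shown here, only one measured step bears on this position, a 1.5-fold higher number from compound 1 to compound 2 (0.19 log units; within the scatter), which exchanged one ring on the amide-type nitrogen for another without moving the number beyond the scatter. Compound 3 returns to a six-membered aromatic ring of carbon only with a bromine, as in compound 1, but without the two fluorines. The two numbers available suggest that this position tolerates exchange, so no step beyond the scatter is expected; the estimated step is a 1.4-fold lower number from compound 2 to compound 3 (0.15 log units; within the scatter), leaning slightly toward compound 1. Compound 3 is therefore expected to give an estimated 1200 nM, within 450 nM to 3200 nM.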

Compound 3, half-maximal inhibitory concentration: 2900 nM
Compound 3: the middle estimate sits 2.4-fold (0.38 log units) below what was measured, and the stated range covers the measured number.
By their numbers in this assay, from the lowest: compounds 1, 2 and 3 (each within the scatter of the next, the first and the last beyond it).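

In this assay, among these compounds, the exchange on the amide-type nitrogen now gives a first step beyond the scatter, though a modest one: a 2.6-fold higher number from compound 1 to compound 3 (0.42 log units; beyond the scatter) arises between two bromine-bearing phenyl groups, 2-bromo-4,6-difluorophenyl and 4-bromophenyl, and not from a change of ring type. The step of a 1.7-fold higher number from compound 2 to compound 3 (0.23 log units; within the scatter) stays within the scatter, so the five-membered 5-methyl-1,2-oxazol-3-yl group of compound 2 is separated from neither phenyl group, and the position cannot be ordered simply as carbon-only ring against hetero ring. The position is therefore not wholly indifferent to exchange, but the size of the separation rests on a single pair, and no measurement at hand accounts for it.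

Because 2-bromo-4,6-difluorophenyl and 4-bromophenyl differ in both the fluorines and the place of the bromine, the compounds shown do not tell which of these features carries the step between compound 1 and compound 3. Also open, on these data alone, is how the position responds to groups outside this small aromatic set, such as an unsubstituted phenyl, a saturated cyclohexyl ring, or a phenyl bearing a carboxylic acid or an amine.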